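This account rests on a few compounds, and the source may have more. Where it says the series, first, only, none or still open, it means among the compounds named here.

Compound 3 `N=C(S)CCCCCCn1nc(-c2ccccc2)ccc1=O` gives 33.9% in a functional assay on the whole organism (stomach) for inhibition, with Rattus norvegicus as the target, at a dose of 100 mg/kg by the intraduodenal route (on this read-out lower numbers stand for less inhibition and higher numbers for more inhibition at the one dose given (going by the name of the read-out)), the highest of the three numbers available. Compound 2 `Cc1ccc(=O)n(CCCCCCC(=N)S)n1` gives 29.5% in this assay, and the change of phenyl in place of methyl on an aromatic carbon produced a number 4.4 percentage points higher from compound 2 to compound 3 (within the scatter). Compound 1 `NC(=O)CCn1nc(-c2ccccc2)ccc1=O` gives -2.8% in this assay, and the change to the longer chain produced a number 36.7 percentage points higher from compound 1 to compound 3 (beyond the scatter).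

Compound 4 `O=C(O)CCn1nc(-c2ccccc2)ccc1=O` differs from compound 3 in that (a group of 3 heavy atoms (1 carbon, 2 oxygen; no ring) in place of a group of 7 heavy atoms (5 carbon, 1 nitrogen, 1 sulfur; no ring), on a saturated chain carbon, two bonds along the chain from an aromatic nitrogen). This change bears on the step between compound 1 and compound 3, in which a three-atom group likewise stood on that chain carbon, since a number 36.7 percentage points higher from compound 1 to compound 3 (beyond the scatter) was large. A change of similar size in the opposite direction is therefore expected, that is a number 28.9 percentage points lower from compound 3 to compound 4 (beyond the scatter). Compound 4 is estimated to give 5% in this assay, between -15% and 25%.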

Compound 4, a percentage reported as inhibition, in the whole organism at one dose (the size of the read-out at that dose, not a potency): 26.1%
The estimate for compound 4 lay 21.1 percentage points below the measured number; the whole stated range lies below it.
By their numbers in this assay, from the lowest: compound 1; then compounds 4, 2 and 3 (each within the scatter of the next).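

Carboxy on the short chain gives a number close to that of the long group in this assay: a number 7.8 percentage points lower from compound 3 to compound 4 (within the scatter), so the long group is not required at this saturated chain carbon. With the chain held constant, hydroxy in place of amino on a carbonyl carbon gives a number 28.9 percentage points higher from compound 1 to compound 4 (beyond the scatter), which shows that the group at the chain end matters on its own, not only chain length. Nothing measured here explains this difference.

As far as these compounds go, it remains open how a longer chain ending in carboxy, or an amine on the short chain, would read in this assay.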